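The source may hold more compounds than are shown below. What is called first, only, known or untested is meant among the compounds shown, and "the series" means these compounds.

Working notes on a small set of nucleoside analogues sharing one core. Compound 1, `OC[C@H]1O[C@@H](n2cnc3c(NCc4cccc(Br)c4)ncnc32)[C@H](O)[C@@H]1O`, carries a bromo group on its aromatic ring and in a functional assay on HL-60 cells (Homo sapiens) for antiproliferative activity, with a stated time of 72 h (a higher number here means a weaker inhibitor, a lower number a stronger inhibitor), compound 1 gives 8000 nM. Compound 2, `COc1cccc(CNc2ncnc3c2ncn3[C@@H]2O[C@H](CO)[C@@H](O)[C@H]2O)c1`, differs only by a methoxy in place of bromo on an aromatic carbon; in this assay compound 2 gives 4900 nM, a step of a 1.6-fold lower number from compound 1 to compound 2 (0.21 log units; within the scatter). Compound 3, `COc1ccc(CNc2ncnc3c2ncn3C2OC(CO)[C@@H](O)[C@H]2O)c(O)c1`, was run but no result was reported, so its entry in this assay reads "not determined" (no result reported).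

Compound 2 thus holds the lowest of the two numbers available, though its nearest neighbour, compound 1, sits within the scatter of it, so no order between them can be read.

Compound 4 is `Cc1cccc(CNc2ncnc3c2ncn3[C@@H]2O[C@H](CO)[C@@H](O)[C@H]2O)c1O`. Relative to compound 2 the difference is 2-hydroxy-3-methylphenyl in place of 3-methoxyphenyl on a saturated chain carbon bound to a nitrogen on an aromatic ring. Among the compounds with values here, only one measured step bears on this change, the swap of bromo for methoxy on the same ring from compound 1 to compound 2, and that step stayed within the scatter. Within the data shown here, no measured step speaks to a hydroxy and a methyl on this ring, and compound 3, which carries a hydroxy there, gives no number. The working expectation is therefore a step of a 1.0-fold higher number from compound 2 to compound 4 (0.01 log units; within the scatter), not beyond the scatter. Compound 4 is estimated at 5000 nM, within 2000 nM to 12000 nM.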

Compound 4, half-maximal inhibitory concentration: 15000 nM
Compound 4: middle estimate off by 3.0-fold (0.48 log units), on the low side; measured number above the stated range.
By their numbers in this assay, from the lowest: compounds 2, 1 and 4 (each within the scatter of the next, the first and the last beyond it).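

In this assay, within the data shown here, 2-hydroxy-3-methylphenyl in place of 3-methoxyphenyl on a saturated chain carbon bound to a nitrogen on an aromatic ring gives the first step in this set to clear the scatter, a 3.1-fold higher number from compound 2 to compound 4 (0.49 log units; beyond the scatter), so the substitution on this ring can shift the number, if only modestly, even with the heavy-atom count unchanged. The same group set against 3-bromophenyl gives a 1.9-fold higher number from compound 1 to compound 4 (0.27 log units; within the scatter), so no order can be read between those two compounds, and the only separation in the set is the one between the methoxy and hydroxy-methyl compounds. Nothing at hand accounts for this step.

From the compounds shown here alone, the change adds a hydroxy and a methyl and removes a methoxy all at once, so it remains open which of these carries the step, and compound 3, the other hydroxy-bearing entry, offers no number to help. Also open, going by these compounds, is how a benzyl carrying only the hydroxy or only the methyl would read here, and how an amine or a carboxylic acid on the same ring would compare.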